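Replacing a methoxyethyl chain with a thiophene carbonyl

A few compounds are considered here, and "the series" means these few. Any claim that something is new, unique, unknown or untested is made for them only; others in the source may bear on it.

Measured in a functional assay (trachea) with Cavia porcellus as the target; on this read-out lower numbers stand for stronger inhibition and higher numbers for weaker inhibition:
- compound 1 `O=c1c2ccccc2c(-c2cccnc2)nn1Cc1cccc(Cl)c1`: 4170 nM
- compound 2 `COCCn1nc(-c2cccnc2)c2ccccc2c1=O`: 9330 nM

Of these two numbers, the higher belongs to compound 2, which makes it the weaker inhibitor of the pair. Still unmeasured is compound 3 `O=C(c1cccs1)n1nc(-c2cccnc2)c2ccccc2c1=O`, which differs from compound 2 in a single place: (thiophen-2-yl)carbonyl in place of 2-methoxyethyl on an aromatic nitrogen.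

For the measured compounds named here, only one measured step bears on this change: a 2.2-fold higher number from compound 1 to compound 2 (0.35 log units; beyond the scatter). That modest step replaced 3-chlorophenyl with methoxymethyl on a saturated chain carbon bound to an aromatic nitrogen, so a chain with a ring gave way to one without. Compound 3 goes the opposite way, regaining a ring, although its ring is a thiophene attached through a carbonyl. Going by the values given here, no measured compound carries such a carbonyl group, so the guide is a loose one.

In this assay a modest move towards a lower number is therefore expected, and a result within the scatter would be no surprise. The expected change is a 1.7-fold lower number from compound 2 to compound 3 (0.23 log units; within the scatter). For compound 3 the estimated value is 5500 nM, with an expected range from 1500 nM to 20000 nM.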

Compound 3, half-maximal inhibitory concentration: 12300 nM
Estimate against measurement, compound 3: 2.2-fold (0.35 log units) below; the range from low to high includes it.
By their numbers in this assay, from the lowest: compound 1; then compounds 2 and 3 (each within the scatter of the next).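

In this assay, putting (thiophen-2-yl)carbonyl in place of 2-methoxyethyl on the aromatic nitrogen gives a small difference (a 1.3-fold higher number from compound 2 to compound 3 (0.12 log units; within the scatter)), so these two very different groups cannot be told apart at this position. Adding a five-membered aromatic ring through a carbonyl therefore does not bring the number back to that of compound 1, and the comparison with the 3-chlorobenzyl group shows a modest gap that lies beyond the scatter (a 2.9-fold higher number from compound 1 to compound 3 (0.47 log units; beyond the scatter)). So a ring on this nitrogen is not enough by itself to match compound 1, and no outside measurement is available to explain these results.

The compounds shown leave open whether the difference from compound 1 lies in the ring itself, in the chlorine it carries, or in the link that joins the ring to the nitrogen. A thiophen-2-ylmethyl group, with a plain carbon in place of the carbonyl, and an unsubstituted benzyl group would help separate these possibilities, while a chain ending in an amine would test a quite different kind of group at this position.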